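This account rests on a few compounds, and the source may have more. Where it says the series, first, only, none or still open, it means among the compounds named here.

Values so far in a physicochemical assay for lipophilicity, using the shake flask method, measured as octanol-water partition; on this read-out higher numbers stand for higher lipophilicity and lower numbers for lower lipophilicity:
- compound 1 `COc1cc(C2=NN(c3ccc(C#N)c(Cl)c3)[C@@H](C3CCCC3)C2)ccc1C(=O)O` gives 2.1
- compound 2 `CCOc1cc(C2=NN(c3ccc(C#N)c(C)c3)[C@@H](C3CCCC3)C2)ccc1C(=O)O` gives 2.7

Of these two numbers, compound 1 (2.1) holds the lower, and compound 2 (2.7) sits higher by more than the usual scatter. These two compounds differ in more than one place, so their gap cannot be tied to any single group.

Compound 3 `COc1cc(C2=NN(c3ccc(C#N)c(C)n3)[C@@H](C3CCCC3)C2)ccc1C(=O)O` has not yet been measured. It keeps the core of compound 1 and changes one group, on an amine nitrogen in a ring: 5-cyano-6-methylpyridin-2-yl in place of 3-chloro-4-cyanophenyl (5-cyano-6-methylpyridin-2-yl in place of 3-chloro-4-cyanophenyl on an amine nitrogen in a ring). For the measured compounds named here, no measured pair shows this exchange alone, so what follows is a judgement. In this assay, a small step toward lower numbers is expected, about the size of the scatter. Starting from compound 1 (2.1), the estimated step (a number 0.30 log units lower from compound 1 to compound 3 (within the scatter)) is modest. For compound 3, the expected value is 1.8, within a range from 1.3 to 2.3.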

Compound 3, distribution coefficient: 1.7
The estimate for compound 3 lay 0.10 log units above the measured number, and the stated range covers the measured number.
By their numbers in this assay, from the lowest: compound 3; then compound 1; then compound 2.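

In this assay, putting 5-cyano-6-methylpyridin-2-yl in place of 3-chloro-4-cyanophenyl on the amine nitrogen in a ring gives a number 0.40 log units lower from compound 1 to compound 3 (beyond the scatter). For the compounds shown here, this is the one comparison here in which only a single place differs, and it shows that this position can move the read-out by more than the usual scatter, even though the two groups hold the same number of heavy atoms and the rest of the molecule stays fixed. No measurement shown here explains the step.

As far as these compounds go, the exchange adds a ring nitrogen and replaces chlorine with methyl at once, so the share of each in the step remains unknown. A pyridine ring carrying chlorine in place of that methyl would help separate the two changes.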